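Chloro to 2-methoxyethoxy on the benzyl ether of compound 2

The compounds below may be only part of what the source reports. "The series", "measured", "known", "first", "only" and "open" are said of these compounds alone.

Series of salicylanilide-type benzyl ethers built on one shared core, assayed in an assay on lysate for inhibition of phosphatidylcholine:ceramide cholinephosphotransferase 2 (Homo sapiens), read by HPLC, with stated times of 30 min and 2 h; on this read-out lower numbers stand for stronger inhibition and higher numbers for weaker inhibition. Compound 1 `O=C(Nc1cccnc1)c1ccccc1OCc1cc(F)ccc1Cl` gives 740 nM. Compound 2 `O=C(Nc1cccnc1)c1ccccc1OCc1cc(Cl)ccc1Cl` gives 990 nM. Compound 3 `Cc1ccc(F)cc1COc1ccccc1C(=O)Nc1cccnc1` gives 740 nM. Among the compounds with values here, the step of a 1.3-fold higher number from compound 1 to compound 2 (0.13 log units; within the scatter) and the step of a 1.3-fold lower number from compound 2 to compound 3 (0.13 log units; within the scatter) both lie within the scatter, as does no change at the digits printed from compound 1 to compound 3 (within the scatter), so nothing separates compound 2 from compounds 1 and 3 on the numbers so far.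

Compound 4 `COCCOc1ccc(Cl)cc1COc1ccccc1C(=O)Nc1cccnc1` differs from compound 2 by 2-methoxyethoxy in place of chloro on an aromatic carbon, placed on an aromatic carbon of a six-membered aromatic ring of carbon only, ortho to a large group and para to a chloro group. The measured steps that touch this ring are the exchanges of small substituents: chloro for fluoro in a 1.3-fold higher number from compound 1 to compound 2 (0.13 log units; within the scatter) and methyl for chloro in no change at the digits printed from compound 1 to compound 3 (within the scatter), all within the scatter. Within the data shown here, no measured step replaces a halogen with a 2-methoxyethoxy chain, so the change in compound 4 is outside what the three compounds cover, and a wide range is carried.

On that basis compound 4 is expected to show no step beyond the scatter, a 1.0-fold higher number from compound 2 to compound 4 (0.00 log units; within the scatter) in this assay, with an estimate of 1000 nM and a range from 300 nM to 3500 nM.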

Compound 4, half-maximal inhibitory concentration: 11600 nM
Beside the measured number, compound 4's estimate is 12-fold (1.06 log units) below it; the measured number lies above the stated range.
By their numbers in this assay, from the lowest: compounds 1, 3 and 2 (each within the scatter of the next); then compound 4.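

In this assay, within the data shown here, this position, ortho to a large group and para to a chloro group, proves sensitive to what it carries: 2-methoxyethoxy in place of chloro gives a 12-fold higher number from compound 2 to compound 4 (1.07 log units; beyond the scatter), the only step so far that lies beyond the scatter. Methyl in place of chloro on an aromatic carbon gave no change at the digits printed from compound 1 to compound 3 (within the scatter), so among the compounds shown the position accepts a methyl but not the 2-methoxyethoxy chain, although that methyl step was read with fluoro rather than chloro on the ring. Nothing measured alongside these numbers bears on what lies behind the rise.

The compounds shown leave open whether the rise follows the length of the chain or its oxygens, which a methoxy, an ethoxy or a plain propyl chain at this position would help to separate. Also open, going by these compounds, is whether a chain ending in an amine or a carboxylic acid would behave like 2-methoxyethoxy, and whether the step keeps its size with fluoro in place of the remaining chloro.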